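Methyl to methoxy on the pendant phenyl of compound 1

The source may report more compounds than this note shows. Statements on the series, on what has been measured and on what is new or still open speak of the compounds shown alone.

Going by the values given here, compound 1 `COc1ncc(-c2ccc3c(c2)N(c2ccc(C)cc2)C(=O)CO3)cc1NS(=O)(=O)c1ccc(F)cc1` is the one member of the series with a number rather than a limit in a functional assay on HeLa cells (Homo sapiens) for antiproliferative activity, read by MTT assay, with a stated time of 72 h; a lower number here means a stronger inhibitor, a higher number a weaker inhibitor; compound 1 gives 4650 nM. Compound 2 `O=C1COc2ccc(-c3cccc(NS(=O)(=O)c4ccc(F)cc4)c3)cc2N1C1CC1` returns only a limit of the assay, > 40000 nM. Compound 3 `COc1cccc(N2C(=O)COc3ccc(-c4cnc(Cl)c(NS(=O)(=O)c5ccc(F)cc5)c4)cc32)c1` likewise stops at a limit, > 40000 nM. Two of the three values thus fall at the same boundary, (the limit of > 40000 nM in this assay, at which 2 of the 3 values shown sit), so the series as a whole reads as weak, and compound 1 is the only anchor for any forecast.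

Compound 4 `COc1ccc(N2C(=O)COc3ccc(-c4cnc(OC)c(NS(=O)(=O)c5ccc(F)cc5)c4)cc32)cc1` has not yet been measured in this assay. It differs from compound 1 in one place: methoxy in place of methyl on an aromatic carbon. The methoxy enters where the methyl leaves, on an aromatic carbon of a six-membered aromatic ring of carbon only, para to a large group; cut one bond further out, the change reads as 4-methylphenyl to 4-methoxyphenyl. Among the compounds with values here, no measured pair carries this change, so nothing here gives its size or direction. The expected step of a 1.3-fold higher number from compound 1 to compound 4 (0.11 log units; within the scatter) is taken to lie within the usual scatter, neither a gain nor a loss that this assay could resolve. Compound 4 is accordingly estimated at 6000 nM, with a range from 2500 nM to 20000 nM.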

Compound 4, half-maximal inhibitory concentration: 1220 nM
The estimate for compound 4 lay 4.9-fold (0.69 log units) above the measured number; measured number outside the range, below it.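

In this assay, going by these compounds alone, the step of a 3.8-fold lower number from compound 1 to compound 4 (0.58 log units; beyond the scatter) is the first change that can be read, and it lies beyond the scatter, though it is modest. It shows that the aromatic carbon para to a large group on the pendant phenyl is not indifferent to what it carries: going from 4-methylphenyl to 4-methoxyphenyl, which adds only an oxygen and one hydrogen-bond acceptor with no ring and no net charge, gives a lower number. Nothing shown explains the size or direction of this step.

From the compounds shown here alone, with a single pair at this position, it remains open whether the lower number follows from the oxygen itself or would also appear with another group there, such as ethoxy, a dimethylamino group or a fluorine atom. Compounds 2 and 3 each differ from compound 4 in more than one place and stay at a limit of the assay, so they offer no comparison for this change: the limit of > 40000 nM in this assay, at which 2 of the 4 values shown sit.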